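Notes on a thiadiazole amide pair: compound 3 to compound 4

A few compounds are considered here, and "the series" means these few. Any claim that something is new, unique, unknown or untested is made for them only; others in the source may bear on it.

Measured so far:
compound 1 `O=C(CSc1ncccn1)Nc1ccc2nc(NC(=O)c3ccc(C(F)(F)F)cc3)sc2c1` — 28100 nM
compound 2 `O=C(CSc1nc2ccccc2[nH]1)Nc1ccc2nc(NC(=O)c3ccc(C(F)(F)F)cc3)sc2c1` — 7110 nM
compound 3 `O=C(CSc1nnc(NC(=O)COc2ccccc2)s1)Nc1ccc(Br)cc1` — > 100000 nM

The read-out is a functional assay on U2OS cells (Homo sapiens) for antiproliferative activity, read by MTT assay, with a stated time of 72 h; a lower number here means a stronger inhibitor, a higher number a weaker inhibitor. Compound 1 gives 28100 nM. Among the compounds with values here, compound 2 gives 7110 nM, and the only measured step, a 4.0-fold lower number from compound 1 to compound 2 (0.60 log units; beyond the scatter), sits on the sulfur of the core shared by compounds 1 and 2. Compound 3 belongs to a different core and gives only a limit, > 100000 nM, so its position on the scale is not a number but the upper edge of the assay, (the limit of > 100000 nM in this assay, at which 1 of the 3 values shown sits).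

The unmeasured compound 4 `COc1ccc(C(=O)Nc2nnc(SCC(=O)Nc3ccc(Br)cc3)s2)cc1OC` differs from compound 3 by 3,4-dimethoxyphenyl in place of phenoxymethyl on a carbonyl carbon. Within the data shown here, no measured step touches a carbonyl carbon or this core, so the step from compound 1 to compound 2 does not bear on it. With compound 3 at a limit, the expected value for compound 4 is 100000 nM, with a range from 30000 nM to 300000 nM, and the expected step of a number no higher from compound 3 to compound 4 (the limit leaves the size open) lies within the scatter; a limit is again the likelier outcome.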

Compound 4, half-maximal inhibitory concentration: > 100000 nM
Compound 4: a limit, no number; the forecaster's own chance of this, stated with the estimate: 65%; the middle value lies on the limit itself.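

Compound 3 and compound 4 each give a limit and not a number, so no step can be read between them: the limit of > 100000 nM in this assay, at which 2 of the 4 values shown sit.

The compounds shown leave open whether 3,4-dimethoxyphenyl in place of phenoxymethyl on a carbonyl carbon changes the result in this assay at all.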